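This account rests on a few compounds, and the source may have more. Where it says the series, first, only, none or still open, it means among the compounds named here.

Compound 1 `CC(C)(C)OC(=O)N1CCC(O[C@H]2CC[C@@H](Oc3ccc(S(C)(=O)=O)cc3)CC2)CC1` gives 266 nM in a functional assay on isolated protein for agonist activity at Glucose-dependent insulinotropic receptor (Homo sapiens), read by HTRF and cAMP accumulation; a lower number here means that less compound is needed, a higher number that more compound is needed for the effect. Compound 2 `CC(C)(C)OC(=O)N1CCC(O[C@H]2CC[C@H](Oc3cnc(C#N)cn3)CC2)CC1` gives 8.3 nM in this assay, and compound 3 `C[C@H](CF)OC(=O)N1CCC(O[C@H]2CC[C@H](Oc3cnc(S(C)(=O)=O)cn3)CC2)CC1` gives 36.8 nM. Compound 3 therefore holds the second highest of the three numbers: compound 2 sits below it by a gap beyond the scatter, and compound 1 sits above it by a gap beyond the scatter. Compound 4 `CS(=O)(=O)c1cnc(O[C@H]2CC[C@H](OC3CCN(CC4(C(F)(F)F)CCCC4)CC3)CC2)cn1` differs from compound 3 in a group of 10 heavy atoms (7 carbon, 3 fluorine; one five-membered non-aromatic ring of carbon only) in place of a group of 7 heavy atoms (4 carbon, 2 oxygen, 1 fluorine; no ring), on an amine nitrogen in a ring. Among the compounds with values here, no pair of measured compounds differing in a single place is available, so no step of this kind has been observed; the change is large, and a modest loss is expected rather than no change. Compound 4 is expected to give 70 nM in this assay, within a range of 15 nM to 350 nM. The expected step is a 1.9-fold higher number from compound 3 to compound 4 (0.28 log units; within the scatter).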

Compound 4, half-maximal effective concentration: 48.8 nM
Estimate against measurement, compound 4: 1.4-fold (0.16 log units) above, and the stated range covers the measured number.
By their numbers in this assay, from the lowest: compound 2; then compounds 3 and 4 (each within the scatter of the next); then compound 1.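

The first step read at this position, on an amine nitrogen in a ring, is a 1.3-fold higher number from compound 3 to compound 4 (0.12 log units; within the scatter) in this assay. The group of 10 heavy atoms, with one five-membered non-aromatic ring of carbon only and 0 hydrogen-bond acceptors, thus stands in for the group of 7 heavy atoms, with 2 hydrogen-bond acceptors and 1 double bond, with no difference beyond the scatter. Nothing available explains this result. This single pair leaves open how a longer chain or a carboxylic acid on that nitrogen would read, and whether the same exchange would hold with the nitrile of compound 2 on the other end of the molecule.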